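The source may report more compounds than this note shows. Statements on the series, on what has been measured and on what is new or still open speak of the compounds shown alone.

Measured so far:
compound 1 `CCN(CC)C(=O)CN(c1ccc(C)cc1)S(=O)(=O)c1ccc(OC(F)(F)F)cc1` with 1820 nM
compound 2 `CCN(CC)C(=O)CN(c1cc(N(CC)CC)ccc1Cl)S(=O)(=O)c1ccc(OC)c(OC)c1` with 2410 nM
compound 3 `CCN(CC)C(=O)CN(c1ccc(C)cc1)S(=O)(=O)c1ccccc1C` with 58 nM

All three were tested in a functional assay on CHO cells for inhibition of Orexin receptor type 2 (Homo sapiens), read by FLIPR and calcium flux; on this read-out lower numbers stand for stronger inhibition and higher numbers for weaker inhibition. Among these numbers, compound 1 gives the second highest. Its nearest neighbour is compound 2, whose value of 2410 nM is within the scatter of that of compound 1, so no order between the two can be claimed. Compound 3 stands furthest away; its number of 58 nM lies well beyond the scatter, far below that of compound 1.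

The step followed here leads from compound 1 to compound 4 `CCN(CC)C(=O)CN(c1ccc(C)cc1)S(=O)(=O)c1ccc(Br)cc1`, which is not yet measured in this assay. The structural difference is bromo in place of trifluoromethoxy on an aromatic carbon, para to a large group. The substituent is exchanged at the same place, and nothing else in the shared core changes.

For the measured compounds named here, no measured pair shows this kind of exchange, so there is no step to lean on. In this assay a modest change in either direction, or none beyond the scatter, is what would be expected. The estimate for compound 4 is therefore 1500 nM, with a range from 400 nM to 5500 nM, which means an expected step of a 1.2-fold lower number from compound 1 to compound 4 (0.08 log units; within the scatter).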

Compound 4, half-maximal inhibitory concentration: 142 nM
Compound 4: middle estimate off by 11-fold (1.02 log units), on the high side, outside the stated range (below it).
By their numbers in this assay, from the lowest: compound 3; then compound 4; then compounds 1 and 2 (each within the scatter of the next).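

In this assay, the place on an aromatic carbon, para to a large group, proves sensitive to the substituent it carries: with bromo in place of trifluoromethoxy there is a 13-fold lower number from compound 1 to compound 4 (1.11 log units; beyond the scatter), a large step from a single exchange, in which a group of 5 heavy atoms gives way to a single bromine atom. For the compounds shown here, compound 4 can also be set against the ortho-free comparison the earlier compounds could not offer, since 4-bromophenyl in place of 2-methylphenyl on the sulfonyl sulfur gives a 2.4-fold higher number from compound 3 to compound 4 (0.39 log units; beyond the scatter), a modest step beyond the scatter that leaves compound 3 with the lower number. Nothing available accounts for the size of either step.

What the compounds shown leave open is how chloro, methyl or a nitrile on the same aromatic carbon would stand against bromo and trifluoromethoxy, and so whether bromo is unusual at this place or trifluoromethoxy is the exception. Also open, on these data alone, is whether the exchange would give a step of similar size if a piperidine took the place of the diethylamino group of the shared core.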